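Aryl swaps on a weakly cytotoxic diterpenoid acid series

The source may hold more compounds than are shown below. What is called first, only, known or untested is meant among the compounds shown, and "the series" means these compounds.

Measured so far:
compound 1 `CC(CC[C@H]1/C(=C/c2ccc([N+](=O)[O-])cc2)CC[C@H]2C(C)(C)CCC[C@]12C)CC(=O)O`: 194000 nM
compound 2 `COc1ccc(/C=C2\CC[C@H]3C(C)(C)CCC[C@]3(C)[C@H]2CCC(C)CC(=O)O)cc1OC`: > 200000 nM (a limit of the assay, not a number)

In an ADME assay on HUVEC cells (Homo sapiens) for cytotoxicity, read by MTT assay, with a stated time of 72 h (a lower number here means a stronger inhibitor, a higher number a weaker inhibitor), compound 1 gives 194000 nM. Compound 2 returns only a limit, > 200000 nM. One of the two values therefore sits at the limit of > 200000 nM in this assay, at which 1 of the 2 values shown sits. Among the measured compounds shown here, the single measured step, an at least 1.0-fold higher number from compound 1 to compound 2 (0.01 log units; that floor lies within the scatter), replaces the aryl group on the same carbon and stays within the scatter. Compound 3 `CC(CC[C@H]1/C(=C/c2ccc(F)cc2)CC[C@H]2C(C)(C)CCC[C@]12C)CC(=O)O` differs from compound 2 by 4-fluorophenyl in place of 3,4-dimethoxyphenyl on a double-bonded chain carbon bound to a double-bonded ring carbon. For the measured compounds named here, this is again an exchange of the aryl group at that position, and the only comparable step, an at least 1.0-fold higher number from compound 1 to compound 2 (0.01 log units; that floor lies within the scatter), showed no movement beyond the scatter, so no step beyond the scatter is expected in this assay for compound 3 either; the estimated step is a number no higher from compound 2 to compound 3 (the limit leaves the size open). For compound 3 the expected value in this assay is 200000 nM, with a range from 100000 nM to 400000 nM. A limit rather than a number is also quite possible for compound 3.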

Compound 3, half-maximal inhibitory concentration: > 200000 nM
Compound 3 was reported as a limit (the forecaster's own chance of this, stated with the estimate: 60%); the middle value sits exactly at the limit.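

In this assay, fluoro in place of nitro on an aromatic carbon gives an at least 1.0-fold higher number from compound 1 to compound 3 (0.01 log units; that floor lies within the scatter), so a second exchange on the aryl ring of compound 1 also shows no step beyond the scatter. The series now covers 4-nitrophenyl, 3,4-dimethoxyphenyl and 4-fluorophenyl on the double-bonded chain carbon bound to a double-bonded ring carbon, and the step between compound 2 and compound 3 cannot be read, as both values are limits. Most of the series now rests on a limit rather than a number: the limit of > 200000 nM in this assay, at which 2 of the 3 values shown sit.

On these data alone, whether an amine on the aromatic ring, or a primary amide in place of the carboxylic acid, would bring a step beyond the scatter stays open. As far as these compounds go, the true values of compound 2 and compound 3 also remain unknown, so any difference between these two aryl groups is hidden.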